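Swapping one aryl group: an expected cytotoxicity value

This account rests on a few compounds, and the source may have more. Where it says the series, first, only, none or still open, it means among the compounds named here.

Measured compounds:
compound 1, `CN(C)CCCNc1nc(-c2ccc(NC(=O)Nc3ccc(Cl)cc3Cl)cc2)nc2c(Cl)c(Cl)sc12`, 1320 nM
compound 2, `Cc1ccc(NC(=O)Nc2ccc(-c3nc(NCCCN(C)C)c4sc(Cl)c(Cl)c4n3)cc2)cc1`, 1320 nM
compound 3, `CCN(CC)CCNc1nc(-c2ccc(NC(=O)Nc3ccc(Cl)cc3Cl)cc2)nc2c(Cl)c(Cl)sc12`, 1140 nM

Of the compounds shown here, three have been tested in a functional assay on HT-29 cells (Homo sapiens) for cytotoxicity, read by MTT assay, with a stated time of 72 h; a lower number here means a stronger inhibitor, a higher number a weaker inhibitor. Compound 1 gives 1320 nM, compound 2 gives 1320 nM, and compound 3 gives 1140 nM. Compound 4, `CCN(CC)CCNc1nc(-c2ccc(NC(=O)Nc3ccc(C)cc3)cc2)nc2c(Cl)c(Cl)sc12`, has not yet been measured in this assay.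

The change from compound 1 to compound 2 is 4-methylphenyl in place of 2,4-dichlorophenyl on an amide-type nitrogen. Its effect was no change at the digits printed from compound 1 to compound 2 (within the scatter).

Compound 3 and compound 4 differ by 4-methylphenyl in place of 2,4-dichlorophenyl on an amide-type nitrogen. The place is worded identically in both pairs, so this is the same change.

The two cores differ by diethylamino in place of (dimethylamino)methyl on a saturated chain carbon, two bonds along the chain from a nitrogen on an aromatic ring, a change that gave a 1.2-fold lower number from compound 1 to compound 3 (0.06 log units; within the scatter).

Since the step between compound 1 and compound 2 was no change at the digits printed from compound 1 to compound 2 (within the scatter), the same change on the core of compound 3 is expected to give a 1.0-fold higher number from compound 3 to compound 4 (0.00 log units; within the scatter). Compound 4 is therefore estimated at 1150 nM in this assay, with the expected range running from 600 nM to 2300 nM. Among the compounds with values here, this expectation rests on only one matched pair, compound 1 and compound 2, and on the value of compound 3, 1140 nM.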

Compound 4, half-maximal inhibitory concentration: 950 nM
Estimate against measurement, compound 4: 1.2-fold (0.08 log units) above; low and high end bracket the measured number.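

In this assay, 4-methylphenyl in place of 2,4-dichlorophenyl on the amide-type nitrogen gave a 1.2-fold lower number from compound 3 to compound 4 (0.08 log units; within the scatter) and behaved alike on both cores: the same change on two cores in this assay, no change at the digits printed (within the scatter) from compound 1 to compound 2 and a 1.2-fold lower number (0.08 log units; within the scatter) from compound 3 to compound 4, 1.2-fold (0.08 log units) apart, within the scatter of two such steps.

Diethylamino in place of (dimethylamino)methyl, read on the 4-methylphenyl pair, gave a 1.4-fold lower number from compound 2 to compound 4 (0.14 log units; within the scatter) and likewise matched its earlier step: the same change on two cores in this assay, a 1.2-fold lower number (0.06 log units; within the scatter) from compound 1 to compound 3 and a 1.4-fold lower number (0.14 log units; within the scatter) from compound 2 to compound 4, 1.2-fold (0.08 log units) apart, within the scatter of two such steps.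

Within the data shown here, every one of these steps lies within the scatter, so the four compounds show only that neither change produced a readable step on either core; they do not show that a change with a real effect would carry from one core to another, and two cores give no rule for the wider series.

What the compounds shown leave open is whether another group on the amide-type nitrogen, such as 4-methoxyphenyl or a pyridyl ring, or a cyclic amine such as morpholine or pyrrolidine in place of diethylamino, would move the number beyond the scatter. As far as these compounds go, all four compounds also keep the chloro groups of the shared core, so the effect of replacing them with hydrogen or methyl remains open as well.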